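Branched against linear alkyl on the pyrazole nitrogen

A few compounds are considered here, and "the series" means these few. Any claim that something is new, unique, unknown or untested is made for them only; others in the source may bear on it.

Compound 1 `Cc1ccc(C(=O)Nc2cccc(C(F)(F)F)c2)cc1-c1ccc2c(-c3cnn(C)c3)n[nH]c2c1` in an assay on isolated protein for inhibition of Discoidin domain-containing receptor 2 (Homo sapiens), read by ELISA, with a stated time of 60 min (on this read-out lower numbers stand for stronger inhibition and higher numbers for weaker inhibition), gives 4.4 nM. Compound 2 `CCn1cc(-c2n[nH]c3cc(-c4cc(C(=O)Nc5cccc(C(F)(F)F)c5)ccc4C)ccc23)cn1` gives 2.6 nM, and compound 3 `CCCn1cc(-c2n[nH]c3cc(-c4cc(C(=O)Nc5cccc(C(F)(F)F)c5)ccc4C)ccc23)cn1` gives 3.2 nM. The steps joining them all stay within the scatter: a 1.7-fold lower number from compound 1 to compound 2 (0.23 log units; within the scatter), a 1.4-fold lower number from compound 1 to compound 3 (0.14 log units; within the scatter) and a 1.2-fold higher number from compound 2 to compound 3 (0.09 log units; within the scatter). Compound 3 therefore stands second highest of the three numbers, with compound 2 nearest and compound 1 furthest, neither gap beyond the scatter.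

Compound 4 `Cc1ccc(C(=O)Nc2cccc(C(F)(F)F)c2)cc1-c1ccc2c(-c3cnn(C(C)C)c3)n[nH]c2c1` differs from compound 3 in one place: isopropyl in place of propyl on an aromatic nitrogen. The two have the same atoms, joined differently. For the measured compounds named here, the steps that bear on this change are the three chain variations already measured, each within the scatter, which suggests the series tolerates alkyl variation at this nitrogen without a clear trend. No branched chain has been measured, so the expectation rests on that tolerance alone. For compound 4 the expected step is no change at the digits printed from compound 3 to compound 4 (within the scatter), none beyond the scatter. Compound 4 is estimated at 3.2 nM, within 1.5 nM to 7 nM.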

Compound 4, half-maximal inhibitory concentration: 7.7 nM
Beside the measured number, compound 4's estimate is 2.4-fold (0.38 log units) below it; measured number outside the range, above it.
By their numbers in this assay, from the lowest: compounds 2, 3, 1 and 4 (each within the scatter of the next, the first and the last beyond it).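

In this assay, the three linear or unbranched variations on this aromatic nitrogen had stayed within the scatter, whereas branching at the carbon bound to it gives a 2.4-fold higher number from compound 3 to compound 4 (0.38 log units; beyond the scatter) for the swap between isomers and a 3.0-fold higher number from compound 2 to compound 4 (0.47 log units; beyond the scatter) from the ethyl analogue, so the arrangement of the chain matters here and not only its carbon count. The tolerance is only partly lost, since the comparison with the methyl analogue gives a 1.8-fold higher number from compound 1 to compound 4 (0.24 log units; within the scatter). No measurement at hand accounts for the effect of branching.

Open, as far as these compounds go, is whether these steps belong to branching in general or to isopropyl alone, which a cyclopropyl or tert-butyl group on this nitrogen would test. Also open, from the compounds shown here alone, is how a longer chain, or one ending in a hydroxyl or an amine, would read in this assay.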